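The source may report more compounds than this note shows. Statements on the series, on what has been measured and on what is new or still open speak of the compounds shown alone.

Compounds measured so far, with their values in an assay on brain for displacement of a labelled ligand from D(3) dopamine receptor (Rattus norvegicus); on this read-out higher numbers stand for weaker inhibition and lower numbers for stronger inhibition:

compound 1, `CCCN(CC[C@H]1CC[C@H](NC(=O)/C=C/c2cccc(F)c2)CC1)[C@H]1CCc2nc(N)sc2C1`, gives 9.9 nM.
compound 2, `CCCN(CC[C@H]1CC[C@H](NS(=O)(=O)c2ccccc2)CC1)[C@H]1CCc2nc(N)sc2C1`, gives 0.79 nM.
compound 3, `CCCN(CC[C@H]1CC[C@H](NS(=O)(=O)c2ccccc2Cl)CC1)[C@H]1CCc2nc(N)sc2C1`, gives 0.68 nM.

Compound 3 has the lowest number of the three in this assay. Its nearest neighbour is compound 2, separated only by a 1.2-fold lower number from compound 2 to compound 3 (0.07 log units; within the scatter), and compound 1 stands far from both, as shown by a 13-fold lower number from compound 1 to compound 2 (1.10 log units; beyond the scatter) and a 15-fold lower number from compound 1 to compound 3 (1.16 log units; beyond the scatter).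

Compound 4, `CCCN(CC[C@H]1CC[C@H](NS(=O)(=O)c2cccc(C)c2)CC1)[C@H]1CCc2nc(N)sc2C1`, is not yet measured. It differs from compound 3 in one place: 3-methylphenyl in place of 2-chlorophenyl on a sulfonyl sulfur. Among the compounds with values here, the only measured step that bears on a change of substituent on the phenyl ring of the sulfonyl group is the one from compound 2 to compound 3, which stayed within the scatter. The two large steps concern the exchange of the whole carbonyl-bearing group for a sulfonyl and do not bear on compound 4, which keeps the sulfonamide. Therefore no step beyond the scatter is expected in this assay; the estimated step of a 1.3-fold higher number from compound 3 to compound 4 (0.12 log units; within the scatter) is taken as a small one. Compound 4 is expected at about 0.9 nM, with a range from 0.3 nM to 2.7 nM.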

Compound 4, inhibition constant: 0.89 nM
For compound 4 the middle estimate is 1.0-fold (0.00 log units) above the measured one, and the stated range covers the measured number.
By their numbers in this assay, from the lowest: compounds 3, 2 and 4 (each within the scatter of the next); then compound 1.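

In this assay methyl joins chloro as a substituent on the phenyl ring of the sulfonamide that stays within the scatter (a 1.1-fold higher number from compound 2 to compound 4 (0.05 log units; within the scatter)), and direct exchange of 2-chlorophenyl for 3-methylphenyl on the sulfonyl sulfur also stays within it (a 1.3-fold higher number from compound 3 to compound 4 (0.12 log units; within the scatter)). The large gap to the amide-bearing compound therefore now holds for a third sulfonamide (an 11-fold lower number from compound 1 to compound 4 (1.05 log units; beyond the scatter)), so it does not depend on which of these three aryl groups sits on the sulfonyl sulfur. No supporting measurement bears on why these aryl changes leave the number within the scatter.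

Open, as far as these compounds go, is whether this flat response extends to a methoxy group, an amine or a carboxylic acid on the phenyl ring. Also open, from the compounds shown here alone, is whether the sulfonyl sulfur tolerates a longer alkyl chain in place of the phenyl ring.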